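This account rests on a few compounds, and the source may have more. Where it says the series, first, only, none or still open, it means among the compounds named here.

Compounds measured in an ADME assay on cells for inhibition of cytochrome P450 11B1, mitochondrial (Homo sapiens), read by HTRF (on this read-out higher numbers stand for weaker inhibition and lower numbers for stronger inhibition), so far:

compound 1 `CC[C@@H]1c2cc(Cl)ccc2C(=O)N1c1cncc2c1CCC[C@H]2NC(C)=O`: 334 nM
compound 2 `CCC(=O)N[C@@H]1CCCc2c1cncc2N1C(=O)c2ccc(Cl)cc2[C@@H]1CC`: 345 nM
compound 3 `CCC(=O)N[C@@H]1CCCc2c1cncc2N1Cc2cc(Cl)ccc2C1=O`: 5210 nM

Compound 2 stands second highest of the three numbers in this assay; its nearest neighbour is compound 1, whose value lies within the scatter of it, and its furthest is compound 3. For the measured compounds named here, the only single-point step in the set, a 15-fold higher number from compound 2 to compound 3 (1.18 log units; beyond the scatter), concerns the ethyl on the saturated ring carbon and is large.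

Compound 4 `CC[C@H]1c2cc(Cl)ccc2C(=O)N1c1cncc2c1CCC[C@H]2NC(C)=O` differs from compound 2 in another place: hydrogen in place of methyl on a saturated chain carbon bound to a carbonyl carbon, i.e. propanoyl to acetyl, propanoylamino to acetamido. Going by the values given here, no measured step bears on this change directly; the step from compound 2 to compound 3 is at a different position and gives no guidance here. Compound 1 also carries an acetamido group and in this assay compound 1 gives 334 nM, within the scatter of compound 2, which suggests the shorter acyl chain is tolerated. The expected step is therefore none beyond the scatter, a 1.0-fold higher number from compound 2 to compound 4 (0.01 log units; within the scatter). For compound 4 the expected value in this assay is 350 nM, with a range of 150 nM to 900 nM.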

Compound 4, half-maximal inhibitory concentration: 3630 nM
For compound 4 the middle estimate is 10-fold (1.02 log units) below the measured one; the measured number lies above the stated range.
By their numbers in this assay, from the lowest: compounds 1 and 2 (each within the scatter of the next); then compounds 4 and 3 (each within the scatter of the next).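

In this assay, an 11-fold higher number from compound 2 to compound 4 (1.02 log units; beyond the scatter) reads as propanoyl to acetyl, but the acyl change alone does not carry it: compound 1 also has the acetamido group and gives 334 nM, within the scatter of compound 2 at 345 nM. With acetamido held constant there is still an 11-fold higher number from compound 1 to compound 4 (1.04 log units; beyond the scatter), so the sensitivity in this series lies with the stereocentre at a saturated ring carbon, drawn R in compound 1 and S in compound 4, and not with acyl length. The large gap is therefore assigned to configuration, because of this: the fact that compounds 1 and 4 differ only in the configuration as drawn

Still open, going by these compounds, is how a butanoyl group or a free amine in place of the acylamino group would read. Also open, on these data alone, is whether methyl or propyl in place of the ethyl keeps the same dependence on configuration, and what inverting the stereocentre that carries the acylamino group would do.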